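This account rests on a few compounds, and the source may have more. Where it says the series, first, only, none or still open, it means among the compounds named here.

Compound 2, with the structure `COc1ccc(CCc2nnc3n2N=C(c2ccc(Cl)cc2)CS3)cc1`, gives 71.5% in a functional assay on the whole organism (strain BALB/c) with Mus musculus as the target, in the writhing test, with a stated time of 1 h, at a dose of 100 mg/kg by the oral route (on this read-out lower numbers stand for a weaker effect and higher numbers for a stronger effect at the one dose given), the highest of the two numbers recorded so far. Within the data shown here, the only other measured compound, compound 1 with the structure `COc1ccc(Cc2n[nH]c(=S)n2N)cc1`, gives 30.2% in this assay, a gap that lies beyond the scatter; no single-point change links these two, so their values can only be set side by side. Compound 3, with the structure `COc1ccc(CCc2nnc3n2N=C(c2ccc(F)cc2)CS3)cc1`, has not yet been measured. It differs from compound 2 in one place: fluoro in place of chloro on an aromatic carbon. The change is small by count, one heavy atom leaving and one entering, with no ring, no donor and no acceptor touched. A step from compound 2 to compound 3 of a number 6.5 percentage points lower from compound 2 to compound 3 (within the scatter) is therefore expected, nothing beyond the scatter. Compound 3 is expected to give about 65% in this assay, most likely between 45% and 85%.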

Compound 3, a percentage reported as inhibition, in the whole organism at one dose (the size of the read-out at that dose, not a potency): 29.2%
The estimate for compound 3 lay 35.8 percentage points above the measured number; the whole stated range lies above it.
By their numbers in this assay, from the lowest: compounds 3 and 1 (each within the scatter of the next); then compound 2.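

In this assay, exchanging 4-chlorophenyl for 4-fluorophenyl brings a number 42.3 percentage points lower from compound 2 to compound 3 (beyond the scatter), so this place on the aromatic ring, para to a large group, is far from indifferent to which halogen it carries. Even a swap of one heavy atom for another, with no ring, donor or acceptor touched, can therefore shift the effect at this one dose as strongly as any difference seen so far. No measurement here explains why the two halogens differ.

From the compounds shown here alone, what a bromo, a methyl or an amine at this same place would give remains open. So does the question of whether the chloro of compound 2 is unusually favourable or the fluoro of compound 3 unusually poor, since a single pair cannot separate the two.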